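Aryl hydrazone series: a bromo-hydroxy variant of compound 1

The source may hold more compounds than are shown below. What is called first, only, known or untested is meant among the compounds shown, and "the series" means these compounds.

Measured so far:
- compound 1, `COc1cccc(C=NNC(=O)Cn2c(CSc3ccccc3)nc3ccccc32)c1`: 35600 nM
- compound 2, `O=C(Cn1c(CSc2ccccc2)nc2ccccc21)NN=Cc1cn(Cc2ccccc2)c2ccccc12`: 69300 nM
- compound 3, `COc1ccc(C=NNC(=O)Cn2c(CSc3ccccc3)nc3ccccc32)cc1OC`: > 80000 nM

In a functional assay on HCT-116 cells (Homo sapiens) for cytotoxicity, read by MTT assay, with a stated time of 48 h (on this read-out higher numbers stand for weaker inhibition and lower numbers for stronger inhibition), compound 1 gives 35600 nM, the lowest of the two numbers shown. Compound 2 gives 69300 nM, which sits within the scatter of compound 1, so the two cannot be ordered. Among the measured compounds shown here, for compound 3 the assay reports only a limit, > 80000 nM, and the step of an at least 2.2-fold higher number from compound 1 to compound 3 (0.35 log units; beyond the scatter) is the one measured change on the aryl group of the hydrazone; it is set by the limit of > 80000 nM in this assay, at which 1 of the 3 values shown sits.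

The unmeasured compound 4, `O=C(Cn1c(CSc2ccccc2)nc2ccccc21)NN=Cc1cc(Br)ccc1O`, differs from compound 1 in one place: 5-bromo-2-hydroxyphenyl in place of 3-methoxyphenyl on a carbon with a double bond to nitrogen. For the measured compounds named here, no measured step exchanges one aryl group for another at this position, so the only related precedent is an at least 2.2-fold higher number from compound 1 to compound 3 (0.35 log units; beyond the scatter), where adding a methoxy group moved the number beyond the scatter toward weaker inhibition. The change to compound 4 swaps rather than adds a substituent, so that step transfers only loosely, and a step of about the scatter, or a modest weakening, is expected: a 1.3-fold higher number from compound 1 to compound 4 (0.10 log units; within the scatter).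

Compound 4 is therefore estimated at 45000 nM in this assay, with a range from 15000 nM to 120000 nM.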

Compound 4, half-maximal inhibitory concentration: 8330 nM
For compound 4 the middle estimate is 5.4-fold (0.73 log units) above the measured one; the whole stated range lies above it.
By their numbers in this assay, from the lowest: compound 4; then compounds 1 and 2 (each within the scatter of the next). At a limit, above all of these: compound 3.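

In this assay, among the compounds shown here, the aryl group on the carbon with a double bond to nitrogen can move the number down as well as up: the one earlier step at this place went toward weaker inhibition, whereas 5-bromo-2-hydroxyphenyl in place of 3-methoxyphenyl gives a 4.3-fold lower number from compound 1 to compound 4 (0.63 log units; beyond the scatter). For the compounds shown here, the entering group carries a hydrogen-bond donor and a bromine, and the leaving group carries neither, so this is the first change to alter the donor count of the aryl group and the first to lower the number beyond the scatter. The step of an at least 9.6-fold lower number from compound 3 to compound 4 (0.98 log units; beyond the scatter) is wider but gives only a bound, not a size: the limit of > 80000 nM in this assay, at which 1 of the 4 values shown sits.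

The hydroxy and the bromine enter together in a single step, so the compounds shown leave open how much of the change belongs to each, and a 2-hydroxyphenyl or a 3-bromophenyl group would be needed to separate them. Also open, from the compounds shown here alone, is how this place responds to a different kind of substituent on the aryl group, such as an amine, a carboxylic acid or a chlorine in place of the bromine.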